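This account rests on a few compounds, and the source may have more. Where it says the series, first, only, none or still open, it means among the compounds named here.

Compound 3 `CCOC(=O)CCCCCOc1cccc(CN(C(=O)c2ccc(-c3ccco3)cc2)C(C)C)c1` was examined in an ADME assay on BJ cells (Homo sapiens) for cytotoxicity, read by CellTiter-Glo and resazurin assay, with a stated time of 72 h; a higher number here means that more compound is needed for the effect, a lower number that less compound is needed. In this assay compound 3 gives > 26000 nM, which is a limit of the assay and not a number. Compound 1 `CCOC(=O)CCCCCOc1cccc(CN(C(=O)c2ccc(-c3cccc4ccccc34)cc2)C(C)C)c1` also reaches only a limit in this assay, at > 26000 nM. Compound 2 `CCOC(=O)CCCCCOc1cccc(CN(C(=O)c2ccc(-c3ccc4ccccc4c3)cc2)C(C)C)c1` likewise gives > 26000 nM, again a limit of the assay. All three values therefore sit at the limit of > 26000 nM in this assay, at which 3 of the 3 values shown sit, and compound 3 stands at that limit with nothing to set it apart from the others.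

Compound 4 `CCOC(=O)CCCCCOc1cccc(CN(C(=O)c2ccc(-c3cccc(OC)c3)cc2)C(C)C)c1` has not been measured; it differs from compound 3 by 3-methoxyphenyl in place of furan-2-yl on an aromatic carbon. Within the data shown here, none of the measured steps can be read: a step that the two limits leave unreadable from compound 1 to compound 2, a step that the two limits leave unreadable from compound 1 to compound 3 and a step that the two limits leave unreadable from compound 2 to compound 3 all run between limits, so their sizes are unknown. Among the measured compounds shown here, no measured step thus shows that exchanging the group on this aromatic carbon moves the value in this assay at all. Compound 4 is expected to stay at the limit too, so the estimated step is a step that the limit leaves unreadable from compound 3 to compound 4. The estimate for compound 4 in this assay is 40000 nM, with a range from 20000 nM to 100000 nM.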

Compound 4, half-maximal effective concentration: > 21000 nM
Compound 4 gave a limit, no number; the forecaster's own chance of this, stated with the estimate: 85%; the middle value is on the limit's open side.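

In this assay compound 4 gives > 21000 nM, which is a limit of the assay and not a number. The steps to compound 4 from compound 1, compound 2 and compound 3 all run between limits and cannot be read. The compounds shown leave open whether exchanging the group on this aromatic carbon moves the value in this assay at all.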